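A few compounds are considered here, and "the series" means these few. Any claim that something is new, unique, unknown or untested is made for them only; others in the source may bear on it.

Of the compounds shown here, three have been tested in a toxicity assay on THP-1 cells (Homo sapiens) for inhibition; a higher number here means that more compound is tolerated, a lower number that less compound is tolerated. Compound 1 `COc1ccc(-c2cn(C)c(NC(=O)c3ccc(F)cc3)n2)cc1` gives only a limit there, > 50000 nM. Compound 3 `COc1ccccc1-c1cnc(NC(=O)c2ncc[nH]2)n1C` also stops at a limit, > 50000 nM. Compound 2 `COc1ccc(-c2cnc(NC(=O)c3cccc(O)c3)n2C)cc1` sits at a limit as well, > 100000 nM. That value is the limit of > 100000 nM in this assay, at which 1 of the 3 values shown sits, while the other two values sit at the limit of > 50000 nM in this assay, at which 2 of the 3 values shown sit. Compound 2 therefore stands where all three do: no toxic concentration was reached within the tested range, and none of the three can be set above or below another. Compound 4 `COc1ccc(-c2cnc(NC(=O)c3ccccc3OC)n2C)cc1` has not been measured yet. It differs from compound 2 in one place: 2-methoxyphenyl in place of 3-hydroxyphenyl on a carbonyl carbon. Among the compounds with values here, with only limits known and no measured step, the step expected for compound 4 is an at least 1.2-fold lower number from compound 2 to compound 4 (0.09 log units; that floor lies within the scatter), nothing beyond the scatter. Compound 4 is expected near 80000 nM, between 30000 nM and 300000 nM, most likely again reported as a limit.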

Compound 4, half-maximal cytotoxic concentration: > 100000 nM
Compound 4 gave a limit, no number; the forecaster's own chance of this, stated with the estimate: 80%; at least 1.2-fold (0.09 log units) between middle value and limit.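

Compound 2 and compound 4 both stop at a limit in this assay, so the step between them cannot be read. The compounds shown leave open at what concentration, if any, toxicity would appear.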